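Adding a Second Ethyl Group to Compound 2

The compounds below may be only part of what the source reports. "The series", "measured", "known", "first", "only" and "open" are said of these compounds alone.

Compound 2 `CCc1ccccc1NC(=O)N[C@H](C)c1ccccc1` gives 101% in an ADME assay on the whole organism with Oryza sativa as the target, tested at 0.1 uM (on this read-out higher numbers stand for a weaker effect at the one concentration tested and lower numbers for a stronger effect), the highest of the three numbers, though the other two lie within the scatter of it: compound 1 `Cc1ccccc1NC(=O)N[C@H](C)c1ccccc1` gives 100%, and compound 3 `C[C@@H](NC(=O)Nc1ccccc1Br)c1ccccc1` gives 99%. Compound 4 `CCc1cccc(CC)c1NC(=O)N[C@H](C)c1ccccc1` differs from compound 2 by ethyl in place of hydrogen on an aromatic carbon. Going by the values given here, two measured steps bear on this change: a number 1 percentage points higher from compound 1 to compound 2 (within the scatter), and a number 2 percentage points lower from compound 2 to compound 3 (within the scatter). Neither change on an aromatic carbon of the shared core moved the read-out beyond the scatter, and all three compounds sit at the same level. The step from compound 2 to compound 4 is therefore expected to be a number 1 percentage points lower from compound 2 to compound 4 (within the scatter), none beyond the scatter. Compound 4 is estimated at 100%, within 90% to 108%.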

Compound 4, a percentage reported as activity, at one concentration (the size of the read-out at that concentration, not a potency): 101%
For compound 4 the middle estimate is 1 percentage points below the measured one, and the stated range covers the measured number.
By their numbers in this assay, from the lowest: compounds 3, 1, 2 and 4 (each within the scatter of the next).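

In this assay, the step of no change at the digits printed from compound 2 to compound 4 (within the scatter) is the first change shown at this position, which carries hydrogen in compound 1, compound 2 and compound 3. It shows that ethyl can take the place of that hydrogen, ortho to a large group and meta to an ethyl group, without moving the read-out beyond the scatter. Nothing available here explains this result. From the compounds shown here alone, whether an amine, a carboxylic acid or a longer chain at this position would leave the read-out equally unchanged remains open.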